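Replacing an aryl acyl with a short chain

The source may hold more compounds than are shown below. What is called first, only, known or untested is meant among the compounds shown, and "the series" means these compounds.

Compound 1 `O=C(Nc1cc(C(F)(F)F)cc(C(F)(F)F)c1)C1CCc2ccccc2N1C(=O)c1ccc(Cl)cc1` is the most potent of the three compounds measured in a functional assay on NCI-H23 cells (Homo sapiens) for cytotoxicity, read by sulforhodamine B assay, with a stated time of 72 h (on this read-out higher numbers stand for weaker inhibition of growth and lower numbers for stronger inhibition of growth), where compound 1 gives 889 nM. The two other measured compounds share neither its amide substituent nor its acyl group. Compound 2 `O=C(Nc1ccccc1O)c1ccc2ccccc2n1` gives 87500 nM in this assay, and compound 3 `CCCCCCCCC(=O)N1c2ccccc2CCC1C(=O)Nc1ccccc1O` gives 55800 nM. Among the compounds with values here, both gaps from compound 1 lie well beyond the scatter, and nothing among the measured compounds separates the effect of the acyl group from that of the amide substituent.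

Compound 4 `CCCC(=O)N1c2ccccc2CCC1C(=O)Nc1cc(C(F)(F)F)cc(C(F)(F)F)c1` keeps the core and the amide substituent of compound 1 and differs only in the acyl group: propyl in place of 4-chlorophenyl on a carbonyl carbon. Within the data shown here, no pair of measured compounds shows this change on its own. Compound 3, whose acyl group is also a plain chain, sits far from compound 1, but it carries a different amide substituent as well, so its value alone cannot set the size of the step. A moderate loss in growth inhibition, beyond the scatter, is expected for compound 4 from the step of a 3.4-fold higher number from compound 1 to compound 4 (0.53 log units; beyond the scatter). Compound 4 is estimated at 3000 nM, within a range from 800 nM to 12000 nM.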

Compound 4, concentration for 50% growth inhibition: 15000 nM
For compound 4 the middle estimate is 5.0-fold (0.70 log units) below the measured one; the whole stated range lies below it.
By their numbers in this assay, from the lowest: compound 1; then compound 4; then compounds 3 and 2 (each within the scatter of the next).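

In this assay, the exchange of 4-chlorophenyl for propyl on a carbonyl carbon gives a 17-fold higher number from compound 1 to compound 4 (1.23 log units; beyond the scatter) and is the first change among the compounds shown to be read on its own, with the core and the amide substituent of compound 1 held fixed. The step shows that the acyl group alone has a large effect on growth inhibition at this position, and that with this amide substituent, the propyl group does not retain the potency of the 4-chlorophenyl group. Nothing available explains the size of this step, although the counts show that the change removes an aromatic ring and a chlorine without altering the number of hydrogen-bond donors or acceptors.

The compounds shown do not separate the loss of the chlorine from the loss of the ring, since neither an unsubstituted phenyl nor a 4-fluorophenyl group appears on this carbonyl carbon with the same amide substituent. Within the data shown here, it also remains open whether a longer chain at this position would behave like propyl, and no pair shows the amide substituent changing on its own.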